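Chloro added to the core: compound 2 to compound 3

The source may hold more compounds than are shown below. What is called first, only, known or untested is meant among the compounds shown, and "the series" means these compounds.

Measured so far, in a functional assay on NCI/ADR-RES cells (Homo sapiens) for cytotoxicity, read by sulforhodamine B assay, with a stated time of 48 h; on this read-out higher numbers stand for weaker inhibition of growth and lower numbers for stronger inhibition of growth:
- compound 1 `ClCc1cccc(Cn2cnc3ncnc(Cl)c32)c1`: 9770 nM
- compound 2 `ClCc1ccccc1Cn1cnc2ncnc(Cl)c21`: 4460 nM

Two compounds share the core and differ only in where the chloromethyl sits on the benzyl ring. Compound 2 carries the lower of the two numbers in this assay; compound 1 is higher by a margin beyond the usual scatter, so compound 2 is the more potent of the pair on this evidence.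

Compound 3 `ClCc1ccccc1Cn1cnc2nc(Cl)nc(Cl)c21` keeps the benzyl part of compound 2 and changes the core: chloro in place of hydrogen on an aromatic carbon. For the measured compounds named here, no measured pair in the set covers this kind of change, so the size of the step is open. With no comparison available, the working expectation is a small step, if any, with a slight lean toward stronger inhibition; the range must stay wide enough to cover no change beyond the scatter in either direction.

The estimated step is a 1.3-fold lower number from compound 2 to compound 3 (0.11 log units; within the scatter). Compound 3 is therefore expected at about 3500 nM in this assay, within 1200 nM to 10000 nM.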

Compound 3, concentration for total growth inhibition: 5010 nM
Compound 3: the middle estimate sits 1.4-fold (0.16 log units) below what was measured; the measured number falls inside the stated range.
By their numbers in this assay, from the lowest: compounds 2, 3 and 1 (each within the scatter of the next, the first and the last beyond it).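

In this assay the added chloro on the aromatic carbon between two ring nitrogen atoms gives a 1.1-fold higher number from compound 2 to compound 3 (0.05 log units; within the scatter) and so leaves the read-out within the scatter. For the compounds shown here, the earlier compounds varied only where the chloromethyl sits on the benzyl ring, so this is the first reading of a change on the core itself, and on this single pair the carbon accepts a chloro in place of hydrogen without a step beyond the scatter. Nothing at hand explains why the step stays this small.

On these data alone, one pair is a thin basis, and it remains open whether the same change on the core of compound 1, with its different chloromethyl placement, would also stay within the scatter. Also open, as far as these compounds go, is whether a different group on this carbon, such as an amine, a methoxy group or a longer alkyl chain, would shift the number in this assay where chloro does not, and whether the chloro already on the core can be replaced by an amine with any effect on growth inhibition.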